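Swapping 4-methylphenyl for a dimethylpyrazole on the sulfonyl sulfur

The compounds below may be only part of what the source reports. "The series", "measured", "known", "first", "only" and "open" are said of these compounds alone.

Compound 1 `CCn1c([C@@H](C)NS(=O)(=O)c2ccc(Cl)cc2)nc2cccc(Cl)c21`: > 100 mL.min-1.g-1
Compound 2 `CCn1c([C@@H](C)NS(=O)(=O)c2ccc(C)cc2)nc2ccc(C(F)(F)F)cc21`: > 100 mL.min-1.g-1

In an ADME assay (liver) for metabolic stability, with Liver microsome (Homo sapiens) as the target, read by LC-MS, using microsomes and NADPH, with a stated time of 5 min, at 37 degrees C (on this read-out lower numbers stand for slow clearance and higher numbers for fast clearance), compound 2 gives > 100 mL.min-1.g-1 as its reading, which is a limit of the assay and not a number. Compound 1 reads > 100 mL.min-1.g-1 in the same way, again a limit and not a number. Taken together, the record so far is the limit of > 100 mL.min-1.g-1 in this assay, at which 2 of the 2 values shown sit, and neither compound therefore offers a numerical value.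

Compound 3 `CCn1c([C@@H](C)NS(=O)(=O)c2cn(C)nc2C)nc2ccc(C(F)(F)F)cc21` shares the core of compound 2 and differs in one place. On a sulfonyl sulfur, 1,3-dimethyl-1H-pyrazol-4-yl stands in place of 4-methylphenyl (1,3-dimethyl-1H-pyrazol-4-yl in place of 4-methylphenyl on a sulfonyl sulfur). Among the measured compounds shown here, no measured pair shows what a change at this place does, and the starting point is not a number, so the size of any step can only be expected. A fall in clearance beyond the usual scatter is expected, with the estimated change an at least 2.5-fold lower number from compound 2 to compound 3 (0.39 log units; beyond the scatter) taken as moderate and not large. For compound 3 the estimate in this assay is 40 mL.min-1.g-1 with an expected range from 12 mL.min-1.g-1 to 100 mL.min-1.g-1 on this read-out.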

Compound 3, intrinsic clearance in microsomes: 28 mL.min-1.g-1
Beside the measured number, compound 3's estimate is 1.4-fold (0.15 log units) above it; the range from low to high includes it.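

In this assay, placing 1,3-dimethyl-1H-pyrazol-4-yl in place of 4-methylphenyl on the sulfonyl sulfur gives an at least 3.5-fold lower number from compound 2 to compound 3 (0.55 log units; beyond the scatter), so this is the first place shown where a single change brings the reading down from the limit to a number. From the compounds shown here alone, compound 2's reading is a limit of the assay and not a number, so the step sets only a minimum and its full size stays unknown. Compound 3 therefore stands apart from the other readings on record, and it gives the series its first number against which later changes can be measured, while the rest remain as follows: the limit of > 100 mL.min-1.g-1 in this assay, at which 2 of the 3 values shown sit.

This single pair cannot separate the effect of exchanging a six-membered aromatic ring of carbon only for a five-membered one from that of the 2 hydrogen-bond acceptors that enter with it, nor show what the two methyl groups on the pyrazole contribute. Going by these compounds, whether a pyridin-3-yl group or an unsubstituted pyrazole on the sulfonyl sulfur would read the same remains open, as does whether the same swap would lower the reading on the core of compound 1.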